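The source may report more compounds than this note shows. Statements on the series, on what has been measured and on what is new or still open speak of the compounds shown alone.

Measured compounds:
Compound 1 `CC(C)(C)c1ccc(S(=O)(=O)Nc2ccccc2)cc1`: 16000 nM
Compound 2 `CC(C)(C)c1ccc(S(=O)(=O)Nc2ccccc2O)cc1`: 13000 nM
Compound 3 `CC(C)(C)c1ccc(S(=O)(=O)Nc2ccc(O)cc2)cc1`: 14000 nM

In a functional assay on A549 cells (Homo sapiens) for inhibition (a higher number here means a weaker inhibitor of growth, a lower number a stronger inhibitor of growth), compound 3 gives 14000 nM, which places it within the scatter of both other compounds. The three values therefore set no order among these compounds.

Compound 4 `Cc1cccc(NS(=O)(=O)c2ccc(C(C)(C)C)cc2)c1` has not yet been measured. It carries 3-methylphenyl in place of 4-hydroxyphenyl on a sulfonamide nitrogen.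

Among the measured compounds shown here, no measured step introduces the methyl group, so the evidence is indirect. Adding a hydroxy group to the unsubstituted aromatic ring gave a 1.2-fold lower number from compound 1 to compound 2 (0.09 log units; within the scatter) and a 1.1-fold lower number from compound 1 to compound 3 (0.06 log units; within the scatter). Changing 2-hydroxyphenyl to 4-hydroxyphenyl gave a 1.1-fold higher number from compound 2 to compound 3 (0.03 log units; within the scatter). All three steps are small, and the change to compound 4 removes the hydroxy group that made so little difference in these steps. A step beyond the scatter in this assay is therefore not expected, and no direction can be favoured with any confidence.

The estimated step is a 1.1-fold lower number from compound 3 to compound 4 (0.03 log units; within the scatter), which is expected to stay within the scatter. The expected value for compound 4 is 13000 nM, with an estimated range from 6500 nM to 26000 nM.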

Compound 4, concentration for 50% growth inhibition: 80000 nM
Compound 4: middle estimate off by 6.2-fold (0.79 log units), on the low side; the whole stated range lies below it.
By their numbers in this assay, from the lowest: compounds 2, 3 and 1 (each within the scatter of the next); then compound 4.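

The group on the sulfonamide nitrogen proved less forgiving than the hydroxy compounds alone had suggested: in this assay, methyl in place of hydrogen on an aromatic carbon gave a 5.0-fold higher number from compound 1 to compound 4 (0.70 log units; beyond the scatter), whereas neither hydroxy step from the same parent, a 1.2-fold lower number from compound 1 to compound 2 (0.09 log units; within the scatter) and a 1.1-fold lower number from compound 1 to compound 3 (0.06 log units; within the scatter), left the scatter. The steps from the two hydroxy compounds are of similar size, a 5.7-fold higher number from compound 3 to compound 4 (0.76 log units; beyond the scatter) and a 6.2-fold higher number from compound 2 to compound 4 (0.79 log units; beyond the scatter), and with all three steps beyond the scatter, compound 4 is the weakest inhibitor of growth of the four, while compounds 1, 2 and 3 remain unordered. Nothing available explains this rise in the number.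

As far as these compounds go, it remains open whether the rise is specific to 3-methylphenyl, or whether an ethyl group, a methoxy group or a chlorine atom on the same ring would give a similar number. The compounds shown also do not tell whether an amine or a carboxylic acid on that ring would keep the number close to those of compounds 1, 2 and 3.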